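The source may hold more compounds than are shown below. What is called first, only, known or untested is meant among the compounds shown, and "the series" means these compounds.

Measured in a functional assay on DU-145 cells (Homo sapiens) for inhibition, read by MTT assay, with stated times of 18 h and 4 h; on this read-out higher numbers stand for weaker inhibition and lower numbers for stronger inhibition:

- compound 1 `CCCCCCCCCCOP(=O)(O)OCCSC(=S)N1CCN(C)CC1`: 82300 nM
- compound 2 `CCCCCCOP(=O)(O)OCCSC(=S)N1CCCCCC1`: 77400 nM
- compound 3 `CCCCCCOP(=O)(O)OCCSC(=S)N1CCCC1`: > 100000 nM (a limit of the assay, not a number)

Compound 3 has no number of its own. In this assay compound 3 stands at > 100000 nM, which is a limit. Within the data shown here, it is the only one of the measured compounds in that position, as the limit of > 100000 nM in this assay, at which 1 of the 3 values shown sits, records.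

The next compound is compound 4 `CCCCCCOP(=O)(O)OCCSC(=S)N1CCN(C)CC1`, which has 4-methylpiperazin-1-yl in place of pyrrolidin-1-yl on a thiocarbonyl carbon. The rest of the structure stays as in compound 3.

Among the measured compounds shown here, one measured step bears directly on this place, and it is an at least 1.2-fold higher number from compound 2 to compound 3 (0.11 log units; that floor lies within the scatter). It shows no size beyond the scatter, so it gives no ground to expect a large move in either direction. Compound 1 also carries 4-methylpiperazin-1-yl, and in this assay compound 1 gives 82300 nM. Compound 2 gives 77400 nM, within the scatter of that value, so neither points to a stronger level.

The expected change is a number no higher from compound 3 to compound 4 (the limit leaves the size open), with no step beyond the scatter anticipated. For compound 4 the estimated value is 100000 nM, with an expected range from 60000 nM to 170000 nM.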

Compound 4, half-maximal inhibitory concentration: > 100000 nM
Compound 4 was reported as a limit; the forecaster's own chance of this, stated with the estimate: 50%; the middle value lies on the limit itself.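

In this assay compound 4, like compound 3, is recorded only as a limit and not as a number, and the step between them cannot be read: the limit of > 100000 nM in this assay, at which 2 of the 4 values shown sit. Against the two compounds with numbers, 4-methylpiperazin-1-yl in place of azepan-1-yl gives an at least 1.2-fold higher number from compound 2 to compound 4 (0.11 log units; that floor lies within the scatter), and hydrogen in place of butyl on a saturated chain carbon gives an at least 1.2-fold higher number from compound 1 to compound 4 (0.08 log units; that floor lies within the scatter). Placing 4-methylpiperazin-1-yl on the thiocarbonyl carbon in place of pyrrolidin-1-yl therefore brings no readable value, and with 4-methylpiperazin-1-yl held fixed, the chain change shows no step beyond the scatter.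

The compounds shown leave open how far compound 3 and compound 4 actually differ, since neither has a number of its own. They also leave open whether morpholin-4-yl on the thiocarbonyl carbon, or a chain longer than that of compound 1, would give a value clearly stronger than those seen here.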